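A few compounds are considered here, and "the series" means these few. Any claim that something is new, unique, unknown or untested is made for them only; others in the source may bear on it.

Notes on the series. Compound 1 `NC1CCN(c2ccc3cc(NC(=O)CCc4ccc(C(F)(F)F)cc4)ccc3n2)C1` gives 200 nM in a functional assay on HEK293 cells for activation of melanin-concentrating hormone receptor 1 (Rattus norvegicus), read by inositol phosphate accumulation; on this read-out lower numbers stand for an effect already at smaller amounts and higher numbers for an effect only at larger amounts of compound. Compound 2 `O=C(CCc1ccc(C(F)(F)F)cc1)Nc1ccc2nc(N3CC4CCC3C4)ccc2c1` gives 150 nM in this assay, and compound 3 `O=C(CCCCCCCCCCCCc1ccc(C(F)(F)F)cc1)Nc1ccc2nc([N+]34CCC(CC3)CC4)ccc2c1` gives 25 nM in this assay. For the measured compounds named here, compound 2 thus stands second highest of the three numbers; nearest to it is compound 1, and the only one-place step in hand, a 1.3-fold lower number from compound 1 to compound 2 (0.12 log units; within the scatter), lies within the scatter. Compound 3 sits furthest from compound 2, but its lower number comes with changes in several places at once, so no single step can be read from that pair.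

Compound 4 `O=C(CCc1ccc(C(F)(F)F)cc1)Nc1ccc2nc(N3CC4CCC3CC4)ccc2c1` is not yet measured. It differs from compound 2 in one place: a group of 8 heavy atoms (7 carbon, 1 nitrogen; 2 six-membered non-aromatic rings with 1 hetero atom each) in place of a group of 7 heavy atoms (6 carbon, 1 nitrogen; one five-membered non-aromatic ring of carbon only, one five-membered non-aromatic ring with 1 hetero atom), on an aromatic carbon. Going by the values given here, the only measured step that bears on this position is a 1.3-fold lower number from compound 1 to compound 2 (0.12 log units; within the scatter), an exchange of the group on the same aromatic carbon that stayed within the scatter. The rest of compound 2 is unchanged in compound 4. No step beyond the scatter is therefore expected in this assay for compound 4; the expected step is a 1.2-fold lower number from compound 2 to compound 4 (0.06 log units; within the scatter). Compound 4 is estimated at 130 nM, with an expected range from 50 nM to 350 nM.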

Compound 4, half-maximal effective concentration: 190 nM
Estimate against measurement, compound 4: 1.5-fold (0.16 log units) below; the range from low to high includes it.
By their numbers in this assay, from the lowest: compound 3; then compounds 2, 4 and 1 (each within the scatter of the next).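

Notes on this position: in this assay, exchanging the group on the aromatic carbon next to the ring nitrogen gives a 1.3-fold higher number from compound 2 to compound 4 (0.10 log units; within the scatter), and the same group in place of the one in compound 1 gives a 1.1-fold lower number from compound 1 to compound 4 (0.02 log units; within the scatter). Across compounds 1, 2 and 4, this position thus takes groups of 6, 7 and 8 heavy atoms, with five- or six-membered non-aromatic rings and with 1 or 2 nitrogen atoms, and every step among them stays within the scatter; this holds for these three compounds only. Nothing in hand bears on why these exchanges leave the number within the scatter.

Still open, going by these compounds, is whether a morpholine or an open-chain dimethylamino group on this carbon, with the rest of compound 2 kept, would give a step beyond the scatter. Compound 3 differs from these compounds in both its chain and its group on this carbon, so the share of each in its number remains unresolved, and a longer chain paired with the group of compound 2 or compound 4 would be needed to separate them.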